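The source may report more compounds than this note shows. Statements on the series, on what has been measured and on what is new or still open speak of the compounds shown alone.

Measured in a physicochemical assay for lipophilicity; on this read-out higher numbers stand for higher lipophilicity and lower numbers for lower lipophilicity:
- compound 1 `CN(C)c1ccc(C(=O)OCC2(CO)C/C(=C\c3ccccn3)C(=O)O2)cc1`: 2.07
- compound 2 `CN(C)c1ccc(C(=O)OCC2(CO)C/C(=C\c3ccc4ccccc4n3)C(=O)O2)cc1`: 3.22
- compound 3 `CN(C)c1ccc(C(=O)OCC2(CO)C/C(=C\c3cnc4ccccc4c3)C(=O)O2)cc1`: 3.22

In this assay compound 3 is level with compound 2 at the digits shown, and the two together hold the top of this small set. For the measured compounds named here, compound 1 is the only clearly separate member, with a number 1.15 log units higher from compound 1 to compound 3 (beyond the scatter).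

The next compound is compound 4 `CN(C)c1ccc(C(=O)OCC2(CO)C/C(=C/c3cnc4ccccc4c3)C(=O)O2)cc1`. Its difference from compound 3 is the two compounds have the same atoms and bonds; at least one stereo element is drawn with a configuration in one of them and without one in the other: 1 of 2 stereo elements differ; a double bond is drawn E in compound 3 and Z in compound 4. The two compounds have the same atoms and bonds, and a double bond is drawn E in compound 3 and Z in compound 4.

Going by the values given here, no measured pair tests this double-bond geometry, so the evidence is indirect. The large steps, a number 1.15 log units higher from compound 1 to compound 2 (beyond the scatter) and a number 1.15 log units higher from compound 1 to compound 3 (beyond the scatter), both replace pyridin-2-yl with a quinolinyl group, and no group is exchanged here, so they offer little guidance. The closer precedent is no change at the digits printed from compound 2 to compound 3 (within the scatter), where quinolin-3-yl takes the place of quinolin-2-yl.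

With that precedent, no step beyond the scatter is expected in this assay, and no direction can be favoured. The estimated change is a number 0.02 log units lower from compound 3 to compound 4 (within the scatter). For compound 4 the expected value is 3.2, with an estimated range of 2.85 to 3.55.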

Compound 4, partition coefficient: 3.22
Compound 4: the middle estimate sits 0.02 log units below what was measured; the measured number falls inside the stated range.
By their numbers in this assay, from the lowest: compound 1; then compounds 2, 3 and 4 (each within the scatter of the next).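

Working notes on the double bond: this is the first pair in the series to test its geometry, and in this assay the reading is no change at the digits printed from compound 3 to compound 4 (within the scatter). All earlier steps exchanged the group on the double-bonded chain carbon, including the large a number 1.15 log units higher from compound 1 to compound 3 (beyond the scatter), whereas here nothing leaves or enters and quinolin-3-yl stays in place, so at this position the read-out shows no step beyond the scatter with atoms and bonds held the same. How cleanly this pair isolates the geometry depends on how the two structures are drawn, and that caveat applies to the reading: the fact that one of compounds 3 and 4 is drawn with a defined configuration and the other without, at the place where they differ

On these data alone, whether the same holds with pyridin-2-yl or quinolin-2-yl on the double-bonded chain carbon remains open, as the geometry is tested only with quinolin-3-yl. Also open, as far as these compounds go, is whether the reading would stay the same with a more strongly ionisable group, such as a carboxylic acid or an amine, in place of quinolin-3-yl, or in any read-out other than this assay.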